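Compound 3 and the 2-carboxyethyl step

A few compounds are considered here, and "the series" means these few. Any claim that something is new, unique, unknown or untested is made for them only; others in the source may bear on it.

In a functional assay on RT16 cells (Cricetulus griseus) for inhibition, read by CellTiter-Blue, with a stated time of 96 h, in the presence of a further agent that is not named here (a higher number here means a weaker inhibitor, a lower number a stronger inhibitor), compound 3 (`Nc1nc2[nH]c(CCCCCCC(=O)O)cc2c(=O)[nH]1`) has no number, only a limit: it gives > 1000 nM as that limit. Compound 1 (`Nc1nc2[nH]c(CCCCCCC(=O)N[C@@H](CCC(=O)O)C(=O)O)cc2c(=O)[nH]1`) gives > 1000 nM as a limit too. Compound 2 (`Nc1nc2[nH]c(CCCCCCCCC(=O)N[C@@H](CCC(=O)O)C(=O)O)cc2c(=O)[nH]1`) gives > 10000 nM as a limit as well. Among the measured compounds shown here, no measured step is available to size the next change. Compound 4 (`Nc1nc2[nH]c(CCCCCCCCC(=O)O)cc2c(=O)[nH]1`) carries 2-carboxyethyl in place of carboxy on a saturated chain carbon, six bonds along the chain from an aromatic carbon, and the counted change is 2-carboxyethyl in place of carboxy on a saturated chain carbon, six bonds along the chain from an aromatic carbon in all. In this assay no gain in strength is expected, only an unchanged or weaker reading, and possibly another limit. The expected step is a step that the limit leaves unreadable from compound 3 to compound 4 by this estimate. The estimate for compound 4 is 5000 nM with an expected range of 1000 nM to 20000 nM for its reading.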

Compound 4, half-maximal inhibitory concentration: > 100 nM
Compound 4 gave a limit, no number; the forecaster's own chance of this, stated with the estimate: 90%; the middle value is on the limit's open side.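

Compound 2, compound 3 and compound 4 all give only limits, so the steps from compound 3 and from compound 2 to compound 4 cannot be read. The compounds shown leave open how strongly any of them inhibits, and whether 2-carboxyethyl in place of carboxy changes the reading at all.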